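The compounds below may be only part of what the source reports. "The series", "measured", "known", "first", "only" and "open" are said of these compounds alone.

Compound 1 `C=C1CC[C@@H]2[C@](C)(COC(=O)CC)[C@H](OC(=O)CC)CC[C@@]2(C)[C@@H]1CCc1ccoc1`: 42900 nM
Compound 2 `C=C1CC[C@@H]2[C@](C)(COC(=O)c3ccc(OC)cc3)[C@H](O)CC[C@@]2(C)[C@@H]1CCc1ccoc1`: 26300 nM
Compound 3 `C[C@]1(CO)[C@H]2CCC(=O)[C@@H](CCc3ccoc3)[C@]2(C)CC[C@H]1O`: > 100000 nM

In a functional assay on NTUB1 cells (Homo sapiens) for cytotoxicity, read by MTT assay, with a stated time of 48 h (a lower number here means a stronger inhibitor, a higher number a weaker inhibitor), compound 1 gives 42900 nM, within the usual scatter of compound 2 at 26300 nM. Compound 3 reads > 100000 nM, which is a limit of the assay and not a number.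

Compound 4 `C=C1[C@H](O)C[C@@H]2[C@](C)(COC(=O)CC)[C@H](OC(=O)CC)CC[C@@]2(C)[C@@H]1CCc1ccoc1` departs from compound 1 by a single change, hydroxy in place of hydrogen on a saturated ring carbon. Going by the values given here, no measured pair of compounds shows this change alone, so no shift beyond the scatter is expected in this assay. The expected step of a 1.1-fold lower number from compound 1 to compound 4 (0.03 log units; within the scatter) is therefore small. For compound 4, the estimate is 40000 nM, with an expected range of 15000 nM to 100000 nM.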

Compound 4, half-maximal inhibitory concentration: 29600 nM
For compound 4 the middle estimate is 1.4-fold (0.13 log units) above the measured one; the measured number falls inside the stated range.
By their numbers in this assay, from the lowest: compounds 2, 4 and 1 (each within the scatter of the next). At a limit, above all of these: compound 3.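

In this assay, hydroxy in place of hydrogen on this saturated ring carbon, two ring bonds from the ring atom that bears the 2-(furan-3-yl)ethyl group, gives a 1.4-fold lower number from compound 1 to compound 4 (0.16 log units; within the scatter). This is the only single-place change among the compounds shown, and it leaves the number within the scatter of the parent. No measurement shown gives a cause for this step.

On these data alone, it remains open whether an amine, a methoxy group or a carboxylic acid on this same carbon would move the number beyond the scatter.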